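This account rests on a few compounds, and the source may have more. Where it says the series, first, only, none or still open, it means among the compounds named here.

Measured so far in a functional assay on HEK293 cells for antagonist activity at metabotropic glutamate receptor 5 (Rattus norvegicus), read by calcium flux; on this read-out higher numbers stand for weaker inhibition and lower numbers for stronger inhibition:

compound 1, `Cc1nc(C#Cc2cc(C#N)cc([N+](=O)[O-])c2)cs1`: 2.63 nM
compound 2, `Cc1nc(C#Cc2cc(Cl)cc(C#N)c2)cs1`: 1.61 nM
compound 3, `Cc1cccc(C#Cc2cc(C#N)cc([N+](=O)[O-])c2)n1`: 3.68 nM

Compound 1 and compound 2 share one core and differ by chloro in place of nitro on an aromatic carbon. This gave a 1.6-fold lower number from compound 1 to compound 2 (0.21 log units; within the scatter), a step that stays inside the usual scatter of this assay.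

Compound 3 carries a different core from compound 1; the difference between the two cores is not broken down here. The values of compound 3 and compound 1 lie within the scatter of each other, so no order between them is claimed. Between compound 3 and compound 2 the gap is beyond the scatter.

Compound 4, `Cc1cccc(C#Cc2cc(Cl)cc(C#N)c2)n1`, is not yet measured. It differs from compound 3 by chloro in place of nitro on an aromatic carbon. Going by the values given here, this is the same kind of change as the one from compound 1 to compound 2, not the same: around the place, the group standing meta is counted as 9 heavy atoms in the core of compound 3 and as 8 heavy atoms in the core of compound 1. Only two such changes occur among these compounds, so the expectation rests on a single measured pair.

From compound 3 to compound 4 the expected step is a 1.6-fold lower number from compound 3 to compound 4 (0.20 log units; within the scatter), resting on compound 1 and compound 2 because a 1.6-fold lower number from compound 1 to compound 2 (0.21 log units; within the scatter) was small. The estimated value for compound 4 in this assay is 2.3 nM. The expected range for compound 4 runs from 1 nM to 5.5 nM. As far as these compounds go, the range is kept wide: whether the step carries over to a second core is untested here.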

Compound 4, half-maximal inhibitory concentration: 1.22 nM
The estimate for compound 4 lay 1.9-fold (0.28 log units) above the measured number, within the range that was stated.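

In this assay, chloro in place of nitro on the core of compound 3 gives a 3.0-fold lower number from compound 3 to compound 4 (0.48 log units; beyond the scatter), a modest step. Set beside the same change on the core of compound 1, the two steps cannot be told apart: the same change on two cores in this assay, a 1.6-fold lower number (0.21 log units; within the scatter) from compound 1 to compound 2 and a 3.0-fold lower number (0.48 log units; beyond the scatter) from compound 3 to compound 4, 1.8-fold (0.27 log units) apart, within the scatter of two such steps

The change therefore carries over to the second core without a measurable difference in step size, even though a 1.6-fold lower number from compound 1 to compound 2 (0.21 log units; within the scatter) stays inside the scatter on its own and only the newer step clears it; this does not show that the two cores respond identically, nor does a comparison of two pairs establish a rule for any further core.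

The compounds shown hold only nitro and chloro at this place, always with the cyano group as the other substituent on that ring, so the effect of a methoxy group, an amine or a carboxylic acid at the same carbon stays open. Also open, as far as these compounds go, is whether the chloro-for-nitro step keeps its size when the cyano group is exchanged for another group, such as a methyl or a trifluoromethyl group.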